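A Bromomethyl Analogue Where Compound 3 Only Gives a Limit

This account rests on a few compounds, and the source may have more. Where it says the series, first, only, none or still open, it means among the compounds named here.

Compound 3 `CCc1cccc2c(OC)c(-c3occ(C)c3COC)ccc12` carries a methoxymethyl group on an aromatic carbon of the shared core. In a functional assay on KB cells (Homo sapiens) for cytotoxicity, read by MTT assay, with a stated time of 72 h (on this read-out lower numbers stand for an effect already at smaller amounts and higher numbers for an effect only at larger amounts of compound), compound 3 gives only a limit, > 10 ug/mL. Compound 1 `CCCOC(=O)c1c(C)coc1-c1ccc2c(CC)cccc2c1OC`, with a propoxycarbonyl group in that place, likewise gives only a limit in this assay, namely > 10 ug/mL. Compound 2 `CCc1cccc2c(OC)c(-c3occ(C)c3CO)ccc12`, with a hydroxymethyl group there, gives 7.1 ug/mL in this assay. The step from compound 1 to compound 2 is an at least 1.4-fold lower number from compound 1 to compound 2 (0.14 log units; that floor lies within the scatter), the step from compound 2 to compound 3 is an at least 1.4-fold higher number from compound 2 to compound 3 (0.14 log units; that floor lies within the scatter), and the step from compound 1 to compound 3 is a step that the two limits leave unreadable from compound 1 to compound 3; the limit of > 10 ug/mL in this assay, at which 2 of the 3 values shown sit, keeps two of these three steps from being read in full.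

Compound 4 `CCc1cccc2c(OC)c(-c3occ(C)c3CBr)ccc12` differs from compound 3 by bromo in place of methoxy on a saturated chain carbon bound to an aromatic carbon. For the measured compounds named here, none of the measured steps exchanges a methoxy for a bromo; they move only among propoxycarbonyl, hydroxymethyl and methoxymethyl, and the nearest of them, the one from compound 2 to compound 3, was an at least 1.4-fold higher number from compound 2 to compound 3 (0.14 log units; that floor lies within the scatter). Since compound 3 stands at a limit, the expected step of an at least 2.0-fold lower number from compound 3 to compound 4 (0.30 log units; that floor lies within the scatter) cannot be anchored to a measured number and is drawn from the spread of the three values shown. Compound 4 is therefore estimated at 5 ug/mL in this assay, within a range from 1 ug/mL to 20 ug/mL, with a real chance that only a limit is again reported.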

Compound 4, concentration for half-maximal effect: > 10 ug/mL
Compound 4: no number, only a limit; the forecaster's own chance of this, stated with the estimate: 40%; middle value at least 2.0-fold (0.30 log units) away from the limit.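

Among the groups shown on this saturated chain carbon bound to an aromatic carbon, bromo alone has no hydrogen-bond acceptor, yet in this assay compound 4 gives > 10 ug/mL, which is a limit and not a number. Bromo in place of hydroxy gives an at least 1.4-fold higher number from compound 2 to compound 4 (0.14 log units; that floor lies within the scatter), so this change shows no difference beyond the scatter, and hydroxy remains the only group at this position with a measured number. The steps from compound 1 and compound 3 to compound 4 cannot be read, and the series now rests mostly on one boundary: the limit of > 10 ug/mL in this assay, at which 3 of the 4 values shown sit.

The compounds shown leave open how far compound 1, compound 3 and compound 4 lie from one another, and whether any group other than hydroxy on this carbon gives a measured number. An amine or an ethoxy group in this place could show whether hydroxy is unusual here or whether other groups also give a measured number.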